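The source may report more compounds than this note shows. Statements on the series, on what has been measured and on what is new or still open speak of the compounds shown alone.

Measured so far in a functional assay for antagonist activity at melanin-concentrating hormone receptor 1 (Homo sapiens), read by GTPgammaS binding; on this read-out higher numbers stand for weaker inhibition and lower numbers for stronger inhibition:
compound 1 `CN(C(=O)N1CC[C@H](n2cnc3cc(-c4ccc(Cl)cc4)sc3c2=O)C1)[C@H]1CCNC1`: 29 nM
compound 2 `CN(C(=O)N1CC[C@H](n2cnc3cc(-c4ccc(Cl)cc4)sc3c2=O)C1)[C@H]1CCN(CC2CC2)C1`: 10 nM

Compound 2 gives the lowest number of the two in this assay; compound 1 sits a step away, a 2.9-fold lower number from compound 1 to compound 2 (0.46 log units; beyond the scatter), so the substituted amine nitrogen is the better of the two shown.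

Compound 3 `CN(C(=O)N1CC[C@H](n2cnc3cc(-c4ccc(Cl)cc4)sc3c2=O)C1)[C@H]1CCN(CC2CCOC2)C1` keeps the substituted amine nitrogen and alters only the group carried on the chain carbon: oxolan-3-yl in place of cyclopropyl on a saturated chain carbon bound to an amine nitrogen in a ring

Among the compounds with values here, only one measured step exists, the one from hydrogen to cyclopropylmethyl on the amine nitrogen, and it does not address an exchange of one ring for another on that chain. It shows that occupying the amine nitrogen helps modestly; it gives no guide to the size of the ring placed there. The step from compound 2 to compound 3 in this assay is therefore expected to stay within the scatter, a 1.5-fold higher number from compound 2 to compound 3 (0.18 log units; within the scatter), with wide uncertainty in either direction.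

Compound 3 is estimated at 15 nM in this assay, within 5 nM to 45 nM.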

Compound 3, half-maximal inhibitory concentration: 10 nM
Estimate against measurement, compound 3: 1.5-fold (0.18 log units) above; low and high end bracket the measured number.
By their numbers in this assay, from the lowest: compounds 2 and 3 (each within the scatter of the next); then compound 1.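

In this assay, cyclopropyl can give way to oxolan-3-yl on the saturated chain carbon, a five-membered ring with one hetero atom and one hydrogen-bond acceptor, with no change at the digits printed from compound 2 to compound 3 (within the scatter) as the result. The gain over hydrogen on the amine nitrogen also holds for the new group, with a 2.9-fold lower number from compound 1 to compound 3 (0.46 log units; beyond the scatter) on record, so two different rings on this chain now carry it. No evidence is available to explain why the exchange leaves the number in place.

Still open, as far as these compounds go, is whether a ring is needed at all on this chain carbon: an open-chain ether such as 2-methoxyethyl on the amine nitrogen would test that in this assay. Also open, from the compounds shown here alone, is how far the position accepts a charged group, such as a carboxylic acid at the end of the chain.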